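Adding One Trifluoromethyl Group to Compound 2

The compounds below may be only part of what the source reports. "The series", "measured", "known", "first", "only" and "open" are said of these compounds alone.

Of the compounds shown here, three have been measured so far in a functional assay on DU-145 cells (Homo sapiens) for antiproliferative activity, read by propidium iodide staining, with a stated time of 96 h; on this read-out lower numbers stand for stronger inhibition and higher numbers for weaker inhibition. Compound 1 `CC(O)(CS(=O)(=O)c1cc(C(F)(F)F)cc(C(F)(F)F)c1)C(=O)Nc1ccc(S(F)(F)(F)(F)F)cc1` gives 24400 nM, compound 2 `CC(O)(CS(=O)(=O)c1cccc(C(F)(F)F)c1)C(=O)Nc1cccc(S(F)(F)(F)(F)F)c1` gives 37300 nM, and compound 3 `CC(O)(CS(=O)(=O)c1ccccc1OC(F)(F)F)C(=O)Nc1cccc(S(F)(F)(F)(F)F)c1` gives 29100 nM. Compound 2 lies within the scatter of both of the others, so these numbers set up no real ranking around it.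

Compound 4 `CC(O)(CS(=O)(=O)c1cc(C(F)(F)F)cc(C(F)(F)F)c1)C(=O)Nc1cccc(S(F)(F)(F)(F)F)c1` differs from compound 2 in one place trifluoromethyl in place of hydrogen on an aromatic carbon, meta to a trifluoromethyl group. Within the data shown here, no measured step tests this addition directly. The nearest evidence is a 1.3-fold lower number from compound 2 to compound 3 (0.11 log units; within the scatter), with 2-(trifluoromethoxy)phenyl in place of 3-(trifluoromethyl)phenyl on the sulfonyl sulfur, which is a different change on the same side of the molecule. Compound 4 also shares its group on the sulfonyl sulfur with compound 1, which gives 24400 nM while differing elsewhere in its structure. With both of these values close to that of compound 2, no change beyond the scatter is expected in this assay. The estimated size of the change is a 1.3-fold lower number from compound 2 to compound 4 (0.12 log units; within the scatter). For compound 4 the expected value is 28000 nM, with an estimated range from 14000 nM to 55000 nM.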

Compound 4, half-maximal inhibitory concentration: 13700 nM
Beside the measured number, compound 4's estimate is 2.0-fold (0.31 log units) above it, and the stated range ends above it.
By their numbers in this assay, from the lowest: compounds 4, 1, 3 and 2 (each within the scatter of the next, the first and the last beyond it).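

Adding a trifluoromethyl group on an aromatic carbon, meta to a trifluoromethyl group, gives a 2.7-fold lower number from compound 2 to compound 4 (0.43 log units; beyond the scatter) in this assay, a modest step but the first one among these compounds that lies beyond the scatter, so this position on the ring attached to the sulfonyl sulfur can alter the read-out, whereas the earlier step at that ring, a 1.3-fold lower number from compound 2 to compound 3 (0.11 log units; within the scatter), could not show this. The other new step, a 1.8-fold lower number from compound 1 to compound 4 (0.25 log units; within the scatter), swaps one group of 12 heavy atoms for another of the same count on the amide-type nitrogen and stays within the scatter, so this pair shows no measurable difference between those two groups when the sulfonyl group is the same. No measured information here explains why the added trifluoromethyl group lowers the number.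

The compounds shown leave open whether this step is specific to trifluoromethyl or whether a methyl group, a chlorine atom or a nitrile in the same place would give a similar number. Going by these compounds, the addition is also seen only once, on the core of compound 2, so whether it gives a step of similar size with a different group on the amide-type nitrogen remains unknown.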